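Two diarylpyrazoles and a methyl for chloro swap

A few compounds are considered here, and "the series" means these few. Any claim that something is new, unique, unknown or untested is made for them only; others in the source may bear on it.

Within the data shown here, the two compounds measured so far share a core carrying two aryl rings. Compound 1, `Clc1ccc(-c2cc(-c3ccccc3)n[nH]2)cc1`, bears a chloro group on one ring and nothing on the other; in an assay on mitochondria from brain for inhibition of Amine oxidase [flavin-containing] A (Bos taurus), read by fluorescence (on this read-out lower numbers stand for stronger inhibition and higher numbers for weaker inhibition), compound 1 gives 302 nM. Compound 2, `Fc1ccc(-c2cc(-c3ccc(Cl)cc3)n[nH]2)cc1`, adds a fluoro group to the second ring, and in this assay compound 2 gives 3.02 nM, the lowest of the two numbers recorded, with compound 1 sitting at the higher number, a gap that lies well beyond the scatter of repeat measurements.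

Compound 3, `Cc1ccc(-c2cc(-c3ccc(F)cc3)[nH]n2)cc1`, keeps the fluorophenyl ring and the core of compound 2 and alters only the other ring: methyl in place of chloro on an aromatic carbon, on an aromatic carbon of a six-membered aromatic ring of carbon only. Among the measured compounds shown here, the data hold no measured pair that isolates a chloro-to-methyl exchange, so the direction and size of the step can only be anticipated. The account expects compound 3 to give 10 nM in this assay, within a range of 2 nM to 50 nM, which amounts to an expected step of a 3.3-fold higher number from compound 2 to compound 3 (0.52 log units; beyond the scatter) from compound 2, a modest weakening that may not exceed the scatter.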

Compound 3, half-maximal inhibitory concentration: 2290 nM
Beside the measured number, compound 3's estimate is 230-fold (2.36 log units) below it; the whole stated range lies below it.
By their numbers in this assay, from the lowest: compound 2; then compound 1; then compound 3.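

With the fluorophenyl ring and the shared core held constant, the exchange of chloro for methyl on an aromatic carbon, para to a large group, gives a 760-fold higher number from compound 2 to compound 3 (2.88 log units; beyond the scatter) in this assay, a large step that gives the first measured view of this position. It shows that inhibition here depends strongly on which group occupies this place, even though the leaving and entering groups each have one heavy atom, no ring, no hydrogen-bond donors or acceptors and no net charge. Those counts therefore do not separate compound 2 from compound 3, and no measurement shown here bears on the reason for the gap.

The compounds shown leave open whether another group at this place, such as bromo, methoxy or an amine, would give a number close to that of compound 2 or to that of compound 3, and thus whether chloro is especially favourable or methyl especially unfavourable. They also leave open whether the same exchange would produce a step of similar size on compound 1, which lacks the fluoro group.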